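The compounds below may be only part of what the source reports. "The series", "measured", "known", "first", "only" and "open" are said of these compounds alone.

Series notes. In a functional assay on the whole organism (artery, strain albino) with Rattus norvegicus as the target, with a stated time of 120 min, at a dose of 10 mg/kg by the oral route (on this read-out lower numbers stand for less inhibition and higher numbers for more inhibition at the one dose given (going by the name of the read-out)), compound 1 `COc1ccc(C2N=C(SCc3ccccc3)NC(C)=C2C(=O)Nc2ccc(F)cc2)cc1OC` gives 8.8% and compound 2 `COc1ccc(C2N=C(SCc3ccccc3Cl)NC(C)=C2C(=O)Nc2ccc(F)cc2)cc1OC` gives 17%; compound 2 thus stands with compound 1 as its only comparator, the two within the scatter of each other. Going by the values given here, the one measured step, a number 8.2 percentage points higher from compound 1 to compound 2 (within the scatter), is chloro in place of hydrogen on an aromatic carbon. Compound 3 `COc1ccc(C2N=C(SCc3cccc(Cl)c3)NC(C)=C2C(=O)Nc2ccc(F)cc2)cc1OC` carries 3-chlorophenyl in place of 2-chlorophenyl on a saturated chain carbon bound to a sulfur. Among the compounds with values here, no measured step moves a chloro from one ring carbon to another, and the step from compound 1 to compound 2 shows only that adding this chloro stayed within the scatter. Compound 3 is therefore expected to stay near compound 2, with a number 2 percentage points lower from compound 2 to compound 3 (within the scatter) meaning no change beyond the scatter, estimated at 15% within 3% to 30%.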

Compound 3, a percentage reported as inhibition, in the whole organism at one dose (the size of the read-out at that dose, not a potency): 10.8%
Compound 3: the middle estimate sits 4.2 percentage points above what was measured; the range from low to high includes it.
By their numbers in this assay, from the lowest: compounds 1, 3 and 2 (each within the scatter of the next).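

Moving the chloro gives the first reading of placement at this position in this assay: the step of a number 6.2 percentage points lower from compound 2 to compound 3 (within the scatter) and the step of a number 2 percentage points higher from compound 1 to compound 3 (within the scatter) both leave the numbers unseparated. Neither 2-chlorophenyl nor 3-chlorophenyl on the saturated chain carbon bound to a sulfur is therefore distinguishable from the other or from the unchlorinated compound 1. No measured evidence bears on this result.

Still open, going by these compounds, is whether an amine or a carboxylic acid in place of the chloro, or a longer chain in place of the benzyl, would give a step beyond the scatter.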